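The compounds below may be only part of what the source reports. "The series", "measured", "known", "first", "only" and "open" are said of these compounds alone.

Values from a functional assay on Malme-3M cells (Homo sapiens) for cytotoxicity, read by sulforhodamine B assay, with a stated time of 48 h, tested at 100 uM (on this read-out lower numbers stand for a stronger effect and higher numbers for a weaker effect at the one concentration tested), for the three measured compounds:

compound 1, `COc1ccc(-c2cc(/C=C/C(=O)c3ccc(N)cc3)[nH]n2)cc1`, gives -82%
compound 2, `COc1ccc(C(=O)/C=C/c2cc(-c3cc(OC)c(OC)c(OC)c3)n[nH]2)cc1OC`, gives -81%
compound 3, `COc1ccc(-c2cc(/C=C/C(=O)c3ccc(N)cc3)[nH]n2)cc1OC`, gives -75%

Compound 1 and compound 3 share one core; compound 3 differs from compound 1 by methoxy in place of hydrogen on an aromatic carbon, and this gave a number 7 percentage points higher from compound 1 to compound 3 (within the scatter). Compound 2 rests on another core, and the difference between the two cores is not broken down here; its value and that of compound 1 lie within the scatter of each other.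

Compound 4, `COc1cc(C(=O)/C=C/c2cc(-c3cc(OC)c(OC)c(OC)c3)n[nH]2)cc(OC)c1OC`, has not been measured. It differs from compound 2 by methoxy in place of hydrogen on an aromatic carbon. The surroundings are not identical: in compound 4 the entering group is also meta to a methoxy group, which the place in compound 3 was not, so this is the same kind of change rather than the same one. For compound 4 a step of a number 3 percentage points higher from compound 2 to compound 4 (within the scatter) is expected, because the earlier step of a number 7 percentage points higher from compound 1 to compound 3 (within the scatter) stayed within the scatter. Compound 4 is therefore estimated at -78%, between -92% and -60%.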

Compound 4, a percentage reported as activity, at one concentration (the size of the read-out at that concentration, not a potency): -94%
The estimate for compound 4 lay 16 percentage points above the measured number, outside the stated range (below it).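

In this assay, methoxy in place of hydrogen on an aromatic carbon gave a number 13 percentage points lower from compound 2 to compound 4 (beyond the scatter). Set beside the earlier step, the same change did not carry over from one core to the other with the same size: the same change on two cores in this assay, a number 7 percentage points higher (within the scatter) from compound 1 to compound 3 and a number 13 percentage points lower (beyond the scatter) from compound 2 to compound 4, 20 percentage points apart, beyond the scatter of two such steps. This shows that, in these two pairs, the earlier step did not predict the later one, but it does not show whether the core itself or the different surroundings of the entering methoxy group account for the gap, and two pairs establish no rule for the series.

The compounds shown leave open whether a hydroxy group or a fluorine atom at that place would behave as methoxy does. They also leave open how both steps would look at other concentrations or in other cell lines.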